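Chain-end exchange on a pyridinylamide series

This account rests on a few compounds, and the source may have more. Where it says the series, first, only, none or still open, it means among the compounds named here.

Measured so far:
compound 1, `O=C(Nc1cccnc1)c1ccccc1OCc1cccc(Cl)c1` — in an assay on lysate for inhibition of phosphatidylcholine:ceramide cholinephosphotransferase 2 (Homo sapiens), read by HPLC, with stated times of 30 min and 2 h (a lower number here means a stronger inhibitor, a higher number a weaker inhibitor), compound 1 gives 1400 nM
compound 2, `COCCCOc1ccc(Cl)cc1COc1ccccc1C(=O)Nc1cccnc1` — in this assay compound 2 gives 4100 nM

Compound 2 carries the highest number of the two measured compounds; its nearest neighbour is compound 1, and the step of a 2.9-fold higher number from compound 1 to compound 2 (0.47 log units; beyond the scatter) lies beyond the scatter, so adding the 3-methoxypropoxy group to the shared core of compound 1 made the inhibitor weaker.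

Compound 3, `CCCCCCCOc1ccc(Cl)cc1COc1ccccc1C(=O)Nc1cccnc1`, has not yet been measured. It differs from compound 2 in one place: butyl in place of methoxy on a saturated chain carbon, three bonds along the chain from an oxygen on an aromatic ring. Read one bond further out, the change is 3-methoxypropyl to heptyl.

Among the measured compounds shown here, only one measured step bears on this change, and only indirectly: the step of a 2.9-fold higher number from compound 1 to compound 2 (0.47 log units; beyond the scatter) shows what the whole 3-methoxypropoxy chain did when it entered. For the measured compounds named here, no measured pair shows what happens when the methoxy at its end is exchanged for butyl. Going by the values given here, with no direct precedent, the expectation for compound 3 is a step of about a 1.1-fold higher number from compound 2 to compound 3 (0.04 log units; within the scatter) relative to compound 2, a shift not clearly beyond the scatter. Compound 3 is therefore estimated at 4500 nM, within a range of 1500 nM to 13000 nM.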

Compound 3, half-maximal inhibitory concentration: 430 nM
Beside the measured number, compound 3's estimate is 10-fold (1.02 log units) above it, and the stated range ends above it.
By their numbers in this assay, from the lowest: compound 3; then compound 1; then compound 2.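

In this assay, among the compounds shown here, the exchange of methoxy for butyl on a saturated chain carbon, three bonds along the chain from an oxygen on an aromatic ring, brings a 9.5-fold lower number from compound 2 to compound 3 (0.98 log units; beyond the scatter) and so shows that the end of the chain matters at this position, which the earlier compounds could not show. Measured against the shared core of compound 1, the two chains also pull in opposite directions: 3-methoxypropoxy brings a 2.9-fold higher number from compound 1 to compound 2 (0.47 log units; beyond the scatter) while heptyloxy brings a 3.3-fold lower number from compound 1 to compound 3 (0.51 log units; beyond the scatter) so a chain at this aromatic carbon can give either a weaker or a stronger inhibitor, depending on what it carries. No evidence is available that bears on what lies behind this reversal.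

The exchange adds chain carbons and removes the methoxy oxygen in one move, so compounds 2 and 3 leave open which of the two changes accounts for the step. Also open, from the compounds shown here alone, is how the number would respond to a longer chain than heptyl, or to a chain of the same length ending in a hydroxyl or an amine.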